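The source may report more compounds than this note shows. Statements on the series, on what has been measured and on what is new or still open speak of the compounds shown alone.

Measured in a functional assay on SEM cells (Homo sapiens) for cytotoxicity, with a stated time of 72 h (on this read-out lower numbers stand for an effect already at smaller amounts and higher numbers for an effect only at larger amounts of compound), the compounds read as follows:
Compound 1 `C=C[C@@](C)(/C=C/c1ccc(OCc2ccccc2)cc1)CCC=C(C)C` gives > 36600 nM as a limit
Compound 2 `C=C[C@@](C)(/C=C/c1ccc(Nc2ccc(OC)cc2)cc1)CCC=C(C)C` gives > 36600 nM as a limit
Compound 3 `C=C[C@@](C)(/C=C/c1ccc(Nc2ccc(OC)c(F)c2)cc1)CCC=C(C)C` gives > 36600 nM as a limit

Within the data shown here, none of the three has yielded a number so far. Compound 3 has only its limit of > 36600 nM to show, and the two compounds before it offer nothing more exact.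

The next compound is compound 4 `C=C[C@@](C)(/C=C/c1ccc(Nc2cc(F)cc(F)c2)cc1)CCC=C(C)C`, which differs from compound 3 in one place (3,5-difluorophenyl in place of 3-fluoro-4-methoxyphenyl on a nitrogen on an aromatic ring). Here 3,5-difluorophenyl stands in place of 3-fluoro-4-methoxyphenyl on a nitrogen on an aromatic ring.

Two measured steps lead up to this change. One exchanged the group on the aromatic carbon (a step that the two limits leave unreadable from compound 1 to compound 2) and the other added a fluoro in place of hydrogen (a step that the two limits leave unreadable from compound 2 to compound 3). Neither gives a size to carry forward because the limit of > 36600 nM in this assay, at which 3 of the 3 values shown sit, leaves no two numbers to compare. The series therefore offers no ground for expecting a shift in either direction in this assay, and a further limit is the likeliest report. The expected change is small, with the estimated step being a number no higher from compound 3 to compound 4 (the limit leaves the size open) and no direction implied. Compound 4 is estimated at 36600 nM with an expected range from 10000 nM to 73000 nM as its likely span.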

Compound 4, half-maximal effective concentration: > 36600 nM
Compound 4: no number, only a limit; the forecaster's own chance of this, stated with the estimate: 80%; the middle value lies on the limit itself.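

In this assay compound 4 gives > 36600 nM, which is a limit and not a number. Its steps from compound 1, compound 2 and compound 3 therefore cannot be read, because no two numbers can be compared: the limit of > 36600 nM in this assay, at which 4 of the 4 values shown sit.

The compounds shown leave open whether any of these changes alters the result in this assay at all.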